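The compounds below may be only part of what the source reports. "The series", "measured", "known", "first", "only" and "open" are said of these compounds alone.

Measured in a functional assay on PC-3M cells (Homo sapiens) for antiproliferative activity, read by microscopy, with a stated time of 24 h; on this read-out lower numbers stand for stronger inhibition and higher numbers for weaker inhibition:
Compound 1 `Cc1c(C)n(Cc2ccccc2)c2ncn(C3CCOCC3)c(=N)c12`: > 20000 nM (a limit)
Compound 2 `Cc1c(C)n(Cc2ccccc2)c2ncn(CCCO)c(=N)c12`: > 20000 nM (a limit)

Compound 2 has no number on this read-out and stands only at a limit, > 20000 nM. The next compound, compound 3 `Cc1c(C)n(Cc2ccccc2)c2ncn([C@H]3CC[C@H](O)CC3)c(=N)c12`, keeps the shared core and has 4-hydroxycyclohexyl in place of 3-hydroxypropyl on an aromatic nitrogen.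

Going by the values given here, only one measured step bears on this change, a step that the two limits leave unreadable from compound 1 to compound 2, and it provides no size to carry forward. It concerns the same nitrogen, where neither oxan-4-yl in compound 1 nor 3-hydroxypropyl in compound 2 gave a number. The evidence amounts to the limit of > 20000 nM in this assay, at which 2 of the 2 values shown sit.

With no readable step as a guide, compound 3 is expected to stay at or near that limit in this assay, though a measurable value cannot be ruled out. No change beyond the scatter is expected, and the estimated a number no higher from compound 2 to compound 3 (the limit leaves the size open) has no firm direction. For compound 3 the estimated value is 20000 nM, with an expected range from 2000 nM to 40000 nM.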

Compound 3, half-maximal inhibitory concentration: > 20000 nM
Compound 3 gave a limit, no number; the forecaster's own chance of this, stated with the estimate: 65%; the middle value sits exactly at the limit.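

In this assay compound 3 gives > 20000 nM as a limit and not a number. Going by these compounds alone, no step among compound 1, compound 2 and compound 3 can be read, and all three stand at one shared limit: the limit of > 20000 nM in this assay, at which 3 of the 3 values shown sit. The compounds shown leave open how far each lies from that limit and whether any group on this aromatic nitrogen changes the read-out.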